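This account rests on a few compounds, and the source may have more. Where it says the series, first, only, none or still open, it means among the compounds named here.

Three compounds have been measured in a physicochemical assay for lipophilicity; on this read-out higher numbers stand for higher lipophilicity and lower numbers for lower lipophilicity:
compound 1 `COc1cccc(CNCc2c(-c3nnc(SC(C)C)n3-c3ccccc3)n(C)c3ccccc23)c1`, which gives 6.27
compound 2 `CC1CCCN(Cc2c(-c3nnc(SC(C)C)n3-c3ccccc3)n(C)c3ccccc23)C1`, which gives 6.03
compound 3 `CC1CCCN(Cc2c(-c3nnc(SC(C)C)n3-c3ccccc3)n(C)c3ccc(F)cc23)C1`, which gives 6.18

Compound 3 has the second highest of the three numbers, but all three lie close together: the steps of a number 0.24 log units lower from compound 1 to compound 2 (within the scatter) and a number 0.15 log units higher from compound 2 to compound 3 (within the scatter) are both within the usual scatter, and the gap between compound 3 and compound 1 is within it as well. Among the measured compounds shown here, on these numbers no compound can be singled out as the most or least lipophilic.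

Compound 4 `CC(C)Sc1nnc(-c2c(CNCC3CC3)c3cc(F)ccc3n2C)n1-c1ccccc1` has not yet been measured. It differs from compound 3 in one place: (cyclopropylmethyl)amino in place of 3-methylpiperidin-1-yl on a saturated chain carbon bound to an aromatic carbon.

For the measured compounds named here, of the two measured steps, only the one from compound 1 to compound 2 touches the same place, the group on the saturated chain carbon bound to an aromatic carbon; that exchange of one amine for another produced a number 0.24 log units lower from compound 1 to compound 2 (within the scatter). The step of a number 0.15 log units higher from compound 2 to compound 3 (within the scatter) concerns a different place and offers no guidance here. The change to compound 4 takes away a six-membered non-aromatic ring with one hetero atom and brings in a group of five heavy atoms with one hydrogen-bond donor, so a downward move in this assay of moderate size is expected, larger than the earlier amine swap. For compound 4 a step of a number 0.58 log units lower from compound 3 to compound 4 (beyond the scatter) is estimated, giving an expected value of 5.6, with a range from 5.1 to 6.1.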

Compound 4, partition coefficient: 5.4
For compound 4 the middle estimate is 0.20 log units above the measured one; measured number inside the range.
By their numbers in this assay, from the lowest: compound 4; then compounds 2, 3 and 1 (each within the scatter of the next).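

In this assay, among the compounds shown here, the exchange of 3-methylpiperidin-1-yl for (cyclopropylmethyl)amino gives a number 0.78 log units lower from compound 3 to compound 4 (beyond the scatter) and is the first step here to clear the scatter. For the compounds shown here, the only earlier change at this place, on a saturated chain carbon bound to an aromatic carbon, gave a number 0.24 log units lower from compound 1 to compound 2 (within the scatter), so the new result shows that the choice of amine here can move the number measurably, though not every exchange does. This single change alters several things at once, taking the group from 7 heavy atoms to 5, replacing a six-membered ring with a three-membered one and going from 0 hydrogen-bond donors to 1, and no measurement available here explains the step or bears on which of these matters.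

The compounds shown do not separate these changes: a ring amine such as pyrrolidin-1-yl would keep the ring nitrogen without a hydrogen-bond donor, while an open-chain butylamino would keep the donor without any ring. Going by these compounds, it also remains open whether the same exchange would give a step of similar size on the core with hydrogen in place of fluoro.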